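Cyclohexyl to benzyl on the amine of a purine-like chloro core

A few compounds are considered here, and "the series" means these few. Any claim that something is new, unique, unknown or untested is made for them only; others in the source may bear on it.

Compound 1 `Cc1ccc(Nc2nc(Cl)nc3c2ncn3Cc2ccc(/C=C/C(=O)Nc3ccccc3N)cc2)cc1`: 33.6%
Compound 2 `Nc1ccccc1NC(=O)c1ccc(Cn2cnc3c(NCc4ccccc4)nc(Cl)nc32)cc1`: 7.55%
Compound 3 `Nc1ccccc1NC(=O)/C=C/c1ccc(Cn2cnc3c(NC4CCCCC4)nc(Cl)nc32)cc1`: 3.83%

The three compounds share a core carrying a chlorine, a benzylic link to a phenyl bearing an amide of an aminophenyl group, and a substituted nitrogen on the aromatic ring. In a functional assay on HepG2 cells (Homo sapiens) for antiproliferative activity, read by CCK-8 assay, with a stated time of 72 h, tested at 2 uM (a higher number here means a stronger effect of the compound at the concentration tested, a lower number a weaker effect), compound 3 gives the lowest of the three numbers. Its nearest neighbour is compound 2, whose value lies within the scatter of it, while compound 1 stands well above it, as the step of a number 29.8 percentage points lower from compound 1 to compound 3 (beyond the scatter) shows: replacing 4-methylphenyl by cyclohexyl on that nitrogen cost a modest but clear part of the effect.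

Compound 4 `Nc1ccccc1NC(=O)/C=C/c1ccc(Cn2cnc3c(NCc4ccccc4)nc(Cl)nc32)cc1` differs from compound 3 in one place: benzyl in place of cyclohexyl on a nitrogen on an aromatic ring. Within the data shown here, no measured step covers exactly this exchange. Among the measured compounds shown here, the one measured step, a number 29.8 percentage points lower from compound 1 to compound 3 (beyond the scatter), concerns the same nitrogen but a different pair of groups. Compound 2, which already carries benzylamino on the core but a different amide linker, gives 7.55%, which lies within the scatter of compound 3.

With a benzyl group entering, the author therefore expects for compound 4 a step of a number 6.2 percentage points higher from compound 3 to compound 4 (within the scatter) in this assay, at most a small rise, and estimates a value of 10%, ranging from 2% to 25%.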

Compound 4, a percentage reported as inhibition, at one concentration (the size of the read-out at that concentration, not a potency): 11.5%
Beside the measured number, compound 4's estimate is 1.5 percentage points below it, within the range that was stated.
By their numbers in this assay, from the lowest: compounds 3, 2 and 4 (each within the scatter of the next); then compound 1.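

In this assay, the exchange of cyclohexyl for benzyl on this nitrogen now has a measured step, a number 7.7 percentage points higher from compound 3 to compound 4 (within the scatter), so these two groups cannot be told apart on this scaffold. Among these compounds, with benzylamino held constant, the result also gives the first reading of the amide side chain, a number 4 percentage points higher from compound 2 to compound 4 (within the scatter), and 2-((2-aminophenyl)carbamoyl)ethenyl and (2-aminophenyl)carbamoyl cannot be separated here either. Of the groups on this nitrogen, 4-methylphenyl alone stands apart, as a number 22.1 percentage points lower from compound 1 to compound 4 (beyond the scatter) adds to a number 29.8 percentage points lower from compound 1 to compound 3 (beyond the scatter), but nothing available accounts for that gap.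

The compounds shown leave open whether the methyl of 4-methylphenyl matters, which an unsubstituted phenyl on this nitrogen would test, and whether 4-methylbenzyl would read like benzyl or like 4-methylphenyl. They also leave open whether 4-methylphenyl would keep its lead with (2-aminophenyl)carbamoyl in place of the 2-((2-aminophenyl)carbamoyl)ethenyl group.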